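Trading a methyl for hydrogen on an aromatic oxygen

The compounds below may be only part of what the source reports. "The series", "measured", "known", "first", "only" and "open" are said of these compounds alone.

Of the compounds shown here, two have been tested in a functional assay on cells (Leukemia cell, Homo sapiens) for cytotoxicity, with a stated time of 48 h; on this read-out higher numbers stand for weaker inhibition of growth and lower numbers for stronger inhibition of growth. Compound 1 `COc1cc(/C=C2\C(=O)N(C)c3ccc(Cl)cc32)cc(OC)c1OC` gives 14400 nM, and compound 2 `COc1ccc2c(c1)/C(=C\c1cc(OC)c(OC)c(OC)c1)C(=O)N2C` gives 7600 nM; these two values lie within the scatter of each other, so neither can be called the stronger. Compound 3 `COc1cc(/C=C2/C(=O)N(C)c3ccc(O)cc32)cc(OC)c1OC` differs from compound 2 by hydrogen in place of methyl on an oxygen on an aromatic ring. For the measured compounds named here, no measured pair shows what this change does, so the size of the step is uncertain; a change no larger than the scatter, in either direction, is the most reasonable expectation. The estimated step from compound 2 to compound 3 is a 1.2-fold lower number from compound 2 to compound 3 (0.07 log units; within the scatter). In this assay compound 3 is expected to give about 6500 nM, within a range from 2200 nM to 20000 nM.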

Compound 3, concentration for total growth inhibition: 8300 nM
Compound 3: middle estimate off by 1.3-fold (0.11 log units), on the low side; the range from low to high includes it.
By their numbers in this assay, from the lowest: compounds 2, 3 and 1 (each within the scatter of the next).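

In this assay, going from methoxy to hydroxy on this aromatic ring gives a 1.1-fold higher number from compound 2 to compound 3 (0.04 log units; within the scatter) and so leaves the compounds indistinguishable. The methyl on this oxygen is therefore not required for the growth inhibition seen with compound 2, and a free hydroxy is tolerated at this position on this read-out. No supporting data bear on this result. As far as these compounds go, it remains open whether an ethoxy group, a longer chain on this oxygen, or an amine in its place would produce a step beyond the scatter.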